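This account rests on a few compounds, and the source may have more. Where it says the series, first, only, none or still open, it means among the compounds named here.

Of the compounds shown here, two have been tested for toxicity, and a third awaits its number. Compound 1, `O=C[C@H](C[C@@H]1CCNC1=O)NC(=O)[C@H](CC1CCCCC1)NC(=O)c1cc2ccccc2[nH]1`, reaches only the assay limit: in a toxicity assay on Huh-7 cells (Homo sapiens) for cytotoxicity (on this read-out lower numbers stand for higher toxicity in this test and higher numbers for lower toxicity in this test), compound 1 gives > 100000 nM, which is a limit rather than a measured number. Going by the values given here, compound 2, `CCCCC1CCC(OC(=O)N[C@@H](CC(C)C)C(=O)N[C@H](C=O)C[C@@H]2CCNC2=O)CC1`, is the one compound with a measured value in this assay, where compound 2 gives 63300 nM. Among the compounds with values here, compound 2 therefore stands as the only real number in this assay, the other entry sitting at the limit of > 100000 nM in this assay, at which 1 of the 2 values shown sits.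

Compound 3, `CCCC1CCC(OC(=O)N[C@@H](CC(C)C)C(=O)N[C@H](C=O)C[C@@H]2CCNC2=O)CC1`, differs from compound 2 in one spot: hydrogen in place of methyl on a saturated chain carbon, three bonds along the chain from a saturated ring carbon. Read one bond further out, the change is butyl to propyl on the chain attached to the saturated ring carbon.

No measured step of this kind exists among these compounds, so the size of the effect in this assay rests on expectation alone. The loss of one chain carbon is expected to move the value, if at all, by a step no larger than the usual scatter, as a 1.2-fold higher number from compound 2 to compound 3 (0.07 log units; within the scatter) expresses. Compound 3 is therefore estimated at 75000 nM, within a range from 35000 nM to 160000 nM in this assay.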

Compound 3, half-maximal cytotoxic concentration: > 100000 nM
Compound 3: only a limit was reported (the forecaster's own chance of this, stated with the estimate: 40%); middle value at least 1.3-fold (0.12 log units) away from the limit.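

Hydrogen in place of methyl on a saturated chain carbon, three bonds along the chain from a saturated ring carbon, now has its first reading in this assay: an at least 1.5-fold higher number from compound 2 to compound 3 (0.19 log units; that floor lies within the scatter). This figure is only a floor and it lies within the scatter, so the shortening of butyl to propyl is not shown to change the read-out by any real amount, and it gives no true size for the step at this position. Going by these compounds alone, the series also gains no second real number, since compound 3 joins compound 1 at the limit and compound 2 remains the only compound with a measured value: the limit of > 100000 nM in this assay, at which 2 of the 3 values shown sit.

As far as these compounds go, how far the true value of compound 3 lies from that of compound 2 stays open, since a limit cannot fix the size of the step. Also open, from the compounds shown here alone, is how this assay would read with a longer chain such as hexyl in place of butyl, or with an amine or a carboxylic acid carried on that chain, where a number below the limit would allow a real comparison.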